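This account rests on a few compounds, and the source may have more. Where it says the series, first, only, none or still open, it means among the compounds named here.

In a functional assay on RPMI-8226 cells (Homo sapiens) for antiproliferative activity, read by radiometric assay, with a stated time of 72 h (on this read-out lower numbers stand for stronger inhibition and higher numbers for weaker inhibition), compound 1 (`Cc1ccc(F)c(Nc2ncnc3cc(NC(=O)CCCCCCC(=O)NO)sc23)c1`) gives 1060 nM and compound 2 (`C#Cc1cccc(Nc2ncnc3cc(NC(=O)CCCCCCC(=O)NO)sc23)c1`) gives 970 nM and the two lie within the scatter of each other. Compound 3 (`CCc1ccc(Nc2ncnc3cc(NC(=O)CCCCCCC(=O)NO)sc23)cc1`) has not yet been measured. It differs from compound 1 by one exchange (4-ethylphenyl in place of 2-fluoro-5-methylphenyl on a nitrogen on an aromatic ring): 4-ethylphenyl in place of 2-fluoro-5-methylphenyl on a nitrogen on an aromatic ring. Within the data shown here, the only measured step at that place is the exchange for 3-ethynylphenyl, a 1.1-fold lower number from compound 1 to compound 2 (0.04 log units; within the scatter) and it stays within the scatter. Among the measured compounds shown here, no measured compound carries 4-ethylphenyl, so the expectation rests on this single step, and no step beyond the scatter is expected in this assay here. The estimated value for compound 3 is 1000 nM with an expected range from 450 nM to 2200 nM as the likely span. That estimate means an expected small change (a 1.1-fold lower number from compound 1 to compound 3 (0.03 log units; within the scatter)).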

Compound 3, half-maximal inhibitory concentration: 2540 nM
Compound 3: middle estimate off by 2.5-fold (0.40 log units), on the low side, and the stated range ends below it.
By their numbers in this assay, from the lowest: compounds 2 and 1 (each within the scatter of the next); then compound 3.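

In this assay, the group on this nitrogen proves not to be freely exchangeable: 4-ethylphenyl gives a 2.4-fold higher number from compound 1 to compound 3 (0.38 log units; beyond the scatter) and a 2.6-fold higher number from compound 2 to compound 3 (0.42 log units; beyond the scatter), so it inhibits modestly more weakly than either earlier group, whereas those two stayed within the scatter of each other. The change from 2-fluoro-5-methylphenyl to 4-ethylphenyl keeps the 8 heavy atoms and the single six-membered aromatic ring of carbon only, so these counts do not separate the two groups. No measurement is available that accounts for the shift.

The compounds shown leave open whether the ethyl group itself or its place on the ring matters. A 3-ethylphenyl, a 4-methylphenyl or a 4-methoxyphenyl on the same nitrogen would bear on that question.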